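This account rests on a few compounds, and the source may have more. Where it says the series, first, only, none or still open, it means among the compounds named here.

Measured so far in an ADME assay on HaCaT cells (Homo sapiens) for inhibition; a higher number here means a weaker inhibitor, a lower number a stronger inhibitor:
compound 1 `COc1cc(-c2cc(C(=O)O)c3ccccc3n2)ccc1OCC(=O)Nc1ccccc1Cl` gives 210000 nM;
compound 2 `COc1cc(-c2cc(C(=O)O)c3ccccc3n2)ccc1OCC(=O)Nc1cccc(Cl)c1` gives 192000 nM;
compound 3 `COc1cc(-c2cc(C(=O)O)c3ccccc3n2)ccc1OCC(=O)NCc1ccccc1` gives only a limit, > 300000 nM.

Compound 3 therefore stands at the limit of this assay (the limit of > 300000 nM in this assay, at which 1 of the 3 values shown sits). Its distance from the other two is not resolved beyond the scatter: an at least 1.4-fold higher number from compound 1 to compound 3 (0.15 log units; that floor lies within the scatter), and an at least 1.5-fold higher number from compound 2 to compound 3 (0.19 log units; that floor lies within the scatter). Compound 4 `COc1cc(-c2cc(C(=O)O)c3ccccc3n2)ccc1OCC(=O)NC1CCCCC1` differs from compound 3 by cyclohexyl in place of benzyl on an amide-type nitrogen. Among the measured compounds shown here, no measured step covers this exchange; the steps that reach compound 3 alter the group on the amide-type nitrogen in other ways, and each of them stays within the scatter. For compound 4 a step of a number no higher from compound 3 to compound 4 (the limit leaves the size open) is therefore expected, none beyond the scatter. Compound 4 is estimated at 300000 nM, in a range from 150000 nM to 700000 nM, and may again be reported only as a limit.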

Compound 4, half-maximal inhibitory concentration: > 300000 nM
Compound 4 ended at the assay's limit; the forecaster's own chance of this, stated with the estimate: 60%; the middle value sits exactly at the limit.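

In this assay, compound 4, with cyclohexyl in place of benzyl on the amide-type nitrogen, joins compound 3 at a limit of the assay: the limit of > 300000 nM in this assay, at which 2 of the 4 values shown sit. The step between these two cannot be read, so the non-aromatic ring and the benzyl group are not told apart here. Against the chlorophenyl compounds, the floors of the two readable steps stay within the scatter: an at least 1.5-fold higher number from compound 2 to compound 4 (0.19 log units; that floor lies within the scatter) and an at least 1.4-fold higher number from compound 1 to compound 4 (0.15 log units; that floor lies within the scatter).

From the compounds shown here alone, how far compound 3 and compound 4 lie past the limit stays open. So does whether an amine or a hydroxyl-bearing chain on this nitrogen would give a number clearly apart from these.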